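Trifluoromethoxy for trifluoromethyl on the shared core

The source may report more compounds than this note shows. Statements on the series, on what has been measured and on what is new or still open speak of the compounds shown alone.

Three members of this series have been measured in a functional assay on T47D cells (Homo sapiens) for inhibition; on this read-out lower numbers stand for stronger inhibition and higher numbers for weaker inhibition. Compound 1 `Oc1ccccc1-c1cc(-c2ccc(F)cc2)cc(-c2ccccc2O)n1` gives > 50000 nM, which is a limit of the assay and not a number. Compound 2 `Oc1ccccc1-c1cc(-c2ccc(C(F)(F)F)cc2)cc(-c2ccccc2O)n1` gives > 50000 nM, again a limit. Compound 3 `Oc1ccc(-c2cc(-c3ccc(C(F)(F)F)cc3)cc(-c3ccccc3O)n2)cc1` gives > 50000 nM, also a limit. Compound 2 therefore cannot be placed relative to the other two, since all three values sit at the limit of > 50000 nM in this assay, at which 3 of the 3 values shown sit. The step that the two limits leave unreadable from compound 1 to compound 2 and the step that the two limits leave unreadable from compound 2 to compound 3 are unreadable for the same reason.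

Compound 4 `Oc1ccccc1-c1cc(-c2ccc(OC(F)(F)F)cc2)cc(-c2ccccc2O)n1` differs from compound 2 by trifluoromethoxy in place of trifluoromethyl on an aromatic carbon. Within the data shown here, no measured step bears directly on this change, and the two steps that touch compound 2 give no readable size. With every measured value at the limit, compound 4 is expected to give a limit in this assay as well, and the expected step is a step that the limit leaves unreadable from compound 2 to compound 4, which could not be read against scatter. The estimate for compound 4 is 60000 nM, with a range from 20000 nM to 200000 nM.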

Compound 4, half-maximal inhibitory concentration: > 50000 nM
Compound 4: no number, only a limit (the forecaster's own chance of this, stated with the estimate: 85%); the middle value is on the limit's open side.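

For compound 4 the value > 50000 nM is a limit and not a number, so the steps joining it to compound 1 and compound 2 cannot be read. The compounds shown leave open whether any change on the shared core gives a measurable value in this assay and how trifluoromethoxy, trifluoromethyl and fluoro compare.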